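Nitro for fluoro on a boron-bearing indole thioether

The source may hold more compounds than are shown below. What is called first, only, known or untested is meant among the compounds shown, and "the series" means these compounds.

In an ADME assay on L929 cells (Mus musculus) for cytotoxicity, read by resazurin assay, with a stated time of 72 h (on this read-out higher numbers stand for weaker inhibition and lower numbers for stronger inhibition), compound 3 `OB1OCc2ccc(-n3cc(Sc4ccc(F)cc4)c4ccccc43)cc21` gives only a limit, > 10 ug/mL. Compound 1 `OB1OCc2ccc(-n3cc(Sc4ccc(O)cc4)c4ccccc43)cc21` also gives only a limit in this assay, > 10 ug/mL. Compound 2 `OB1OCc2ccc(-n3cc(Sc4cccc(Cl)c4)c4ccccc43)cc21` likewise gives only a limit in this assay, > 10 ug/mL. The steps a step that the two limits leave unreadable from compound 1 to compound 2, a step that the two limits leave unreadable from compound 1 to compound 3 and a step that the two limits leave unreadable from compound 2 to compound 3 therefore have no readable size, as the limit of > 10 ug/mL in this assay, at which 3 of the 3 values shown sit, shows. Compound 4 `O=[N+]([O-])c1ccc(Sc2cn(-c3ccc4c(c3)B(O)OC4)c3ccccc23)cc1` differs from compound 3 by nitro in place of fluoro on an aromatic carbon. Within the data shown here, since none of the measured steps has a readable size, no direction beyond the scatter can be set for this assay from them. The step that the limit leaves unreadable from compound 3 to compound 4 is expected to stay small. Compound 4 is estimated at 20 ug/mL in this assay, with a range from 5 ug/mL to 80 ug/mL, most probably reported once more only as a limit.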

Compound 4, half-maximal inhibitory concentration: > 10 ug/mL
Compound 4: no number, only a limit (the forecaster's own chance of this, stated with the estimate: 80%); the middle value lies beyond the limit too.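

The steps from compound 1, compound 2 and compound 3 to compound 4 cannot be read, as all end on a limit: the limit of > 10 ug/mL in this assay, at which 4 of the 4 values shown sit. The compounds shown leave open whether these groups on sulfur differ in cytotoxicity at all.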